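Varying the heteroaryl on the sulfur of a urea series

The source may report more compounds than this note shows. Statements on the series, on what has been measured and on what is new or still open speak of the compounds shown alone.

Measured compounds:
Compound 1 `CCCCCCCN(CCCCCSc1nc(O)c2ccccc2n1)C(=O)Nc1ccc(F)cc1F` — 4000 nM
Compound 2 `CCCCCCCN(CCCCCSc1ncccn1)C(=O)Nc1ccc(F)cc1F` — 3300 nM
Compound 3 `CCCCCCCN(CCCCCSc1[nH]cnc2nncc1-2)C(=O)Nc1ccc(F)cc1F` — 710 nM

The three compounds share a core and differ only in the aromatic group attached to the sulfur at the end of the chain. In an assay on microsomes from liver for inhibition of sterol O-acyltransferase 1 (Rattus norvegicus) (a higher number here means a weaker inhibitor, a lower number a stronger inhibitor), compound 1 gives 4000 nM and compound 2 gives 3300 nM; the step of a 1.2-fold lower number from compound 1 to compound 2 (0.08 log units; within the scatter) lies within the scatter. Compound 3 gives 710 nM, the lowest of the three numbers, and both steps leading to it are beyond the scatter: a 5.6-fold lower number from compound 1 to compound 3 (0.75 log units; beyond the scatter) and a 4.6-fold lower number from compound 2 to compound 3 (0.67 log units; beyond the scatter).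

Compound 4 `CCCCCCCN(CCCCCSc1n[nH]c(-c2ccccc2)n1)C(=O)Nc1ccc(F)cc1F` has not been measured in this assay. It differs from compound 3 by a group of 11 heavy atoms (8 carbon, 3 nitrogen; one five-membered aromatic ring with 3 hetero atoms, one six-membered aromatic ring of carbon only) in place of a group of 9 heavy atoms (5 carbon, 4 nitrogen; one five-membered aromatic ring with 2 hetero atoms, one six-membered aromatic ring with 2 hetero atoms), on a sulfur. Within the data shown here, no measured step covers this exchange directly. Among the measured compounds shown here, the steps that bear on it show only that two six-membered heteroaryl groups on the sulfur sat close together and that the fused bicyclic group of compound 3 lowered the number modestly. Since compound 4 gives up that bicyclic group, the number is expected to rise, by roughly a 2.8-fold higher number from compound 3 to compound 4 (0.45 log units; beyond the scatter), back toward the range of compounds 1 and 2. Compound 4 is therefore estimated at 2000 nM, within 600 nM to 6500 nM.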

Compound 4, half-maximal inhibitory concentration: 4000 nM
Compound 4: the middle estimate sits 2.0-fold (0.30 log units) below what was measured; the measured number falls inside the stated range.
By their numbers in this assay, from the lowest: compound 3; then compounds 2, 1 and 4 (each within the scatter of the next).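

At this place on the sulfur, the 5-phenyl-1H-1,2,4-triazol-3-yl group does not retain the lower number of compound 3 in this assay and gives a 5.6-fold higher number from compound 3 to compound 4 (0.75 log units; beyond the scatter) in that assay. The steps of a 1.2-fold higher number from compound 2 to compound 4 (0.08 log units; within the scatter) and no change at the digits printed from compound 1 to compound 4 (within the scatter) both lie within the scatter, so a five-membered aromatic ring carrying a phenyl group joins the two earlier groups, and among the four compounds only compound 3 stands apart. No measured evidence is available to explain what sets the group of compound 3 apart from the other three.

The compounds shown do not separate the fused ring pair of compound 3 from its particular arrangement of nitrogen atoms as the feature tied to its lower number. They also leave open how in this assay an unsubstituted 1H-1,2,4-triazol-3-yl or a benzimidazol-2-yl on the sulfur would compare.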